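This account rests on a few compounds, and the source may have more. Where it says the series, first, only, none or still open, it means among the compounds named here.

In a functional assay on SNU-638 cells (Homo sapiens) for antiproliferative activity, read by sulforhodamine B assay, with a stated time of 72 h (a lower number here means a stronger inhibitor, a higher number a weaker inhibitor), compound 1 (`CCCCS(=O)(=O)Nc1cc(-c2ccc3ncnc(NCCN(C)C)c3c2)cnc1OC`) gives 480 nM, while compound 2 (`CCCCS(=O)(=O)Nc1cc(-c2ccc3ncnc(NCc4ccncc4)c3c2)cnc1OC`) gives 6660 nM, the higher of the two numbers. The measured step, a 14-fold higher number from compound 1 to compound 2 (1.14 log units; beyond the scatter), is large and beyond the scatter, but it lies on a saturated chain carbon, not at the sulfonyl. Compound 3 (`COc1ncc(-c2ccc3ncnc(NCc4ccncc4)c3c2)cc1NS(=O)(=O)c1ccc(F)cc1F`) brings a different change: 2,4-difluorophenyl in place of butyl on a sulfonyl sulfur. For the measured compounds named here, no measured step covers this swap of 2,4-difluorophenyl for butyl, so its size is poorly known. The expected step is a 4.4-fold lower number from compound 2 to compound 3 (0.65 log units; beyond the scatter), a tentative move towards a lower number. For compound 3 the estimated value is 1500 nM, with an expected range of 200 nM to 8000 nM.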

Compound 3, half-maximal inhibitory concentration: 6210 nM
Compound 3: middle estimate off by 4.1-fold (0.62 log units), on the low side, and the stated range covers the measured number.
By their numbers in this assay, from the lowest: compound 1; then compounds 3 and 2 (each within the scatter of the next).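

On the sulfonyl sulfur, with the pyridin-4-yl side chain held fixed, replacing butyl with 2,4-difluorophenyl in this assay gives only a small step (a 1.1-fold lower number from compound 2 to compound 3 (0.03 log units; within the scatter)). A chain and an aromatic ring with more heavy atoms therefore cannot be told apart here, so this change leaves the number essentially unmoved, unlike the large side-chain step seen earlier. Nothing available explains this result.

As far as these compounds go, it remains open whether the two sulfonyl groups would also read alike with the (dimethylamino)methyl side chain of compound 1. Also open, from the compounds shown here alone, is how a sulfonyl group carrying an amine or a carboxylic acid would compare.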